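Swapping chloro for hydroxy on the aromatic ring

The source may report more compounds than this note shows. Statements on the series, on what has been measured and on what is new or still open speak of the compounds shown alone.

Of the compounds shown here, two with a shared core have been measured in a functional assay for antagonist activity at Adrenergic receptor alpha-1 (Rattus norvegicus); a lower number here means tighter binding, a higher number weaker binding. Compound 1 `COc1cccc(OC)c1OCCNC[C@H]1Oc2ccccc2O[C@@H]1C` gives 11.5 nM in this assay. Compound 2 `COc1cccc(OC)c1OCCNC[C@H]1Oc2ccccc2O[C@@H]1c1ccc(Cl)cc1` gives 7.08 nM. For the measured compounds named here, the single step between them, a 1.6-fold lower number from compound 1 to compound 2 (0.21 log units; within the scatter), puts a 4-chlorophenyl in place of a methyl on a saturated ring carbon. Compound 2 thus holds the lower of the two numbers, but compound 1 lies within the scatter of it, so the two cannot be told apart.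

Compound 3 `COc1cccc(OC)c1OCCNC[C@H]1Oc2ccccc2O[C@@H]1c1ccc(O)cc1` has not yet been measured. It differs from compound 2 by hydroxy in place of chloro on an aromatic carbon. Going by the values given here, no measured step touches this place: the one step recorded exchanges the whole group on the saturated ring carbon, not a group on the six-membered aromatic ring of carbon only, and that step itself stays within the scatter. With no direct guide, a change no larger than the scatter is expected, a 1.4-fold higher number from compound 2 to compound 3 (0.15 log units; within the scatter). Compound 3 is therefore estimated at 10 nM in this assay, with a range from 4 nM to 30 nM.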

Compound 3, dissociation constant: 14.5 nM
Compound 3: middle estimate off by 1.5-fold (0.16 log units), on the low side, and the stated range covers the measured number.
By their numbers in this assay, from the lowest: compounds 2, 1 and 3 (each within the scatter of the next, the first and the last beyond it).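

In this assay, for the compounds shown here, hydroxy in place of chloro on an aromatic carbon, para to a large group, gives a 2.0-fold higher number from compound 2 to compound 3 (0.31 log units; beyond the scatter) and is the first step to pass beyond the scatter, though only modestly. This shows that the group at this position can shift the number, even when only the atom or group at the end of the 4-substituted phenyl changes. The other new step, a 1.3-fold higher number from compound 1 to compound 3 (0.10 log units; within the scatter), stays within the scatter, so neither 4-chlorophenyl nor 4-hydroxyphenyl is set apart from methyl on the saturated ring carbon, even though the two differ measurably from each other. Hydroxy brings a hydrogen-bond donor and a hydrogen-bond acceptor that chloro lacks, but no evidence at hand accounts for the shift.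

This position is described by only two groups, so the compounds shown leave open how a fluoro, a methoxy or an amine in the same place would compare with chloro and hydroxy. They also leave open whether the same exchange would give a similar step on another carbon of that ring or with a different group on the rest of the shared core.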